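Uracil attachment isomer of a sulfonamide series

This account rests on a few compounds, and the source may have more. Where it says the series, first, only, none or still open, it means among the compounds named here.

Within the data shown here, compound 1 `COC(CN(c1ccccc1CO)S(=O)(=O)c1ccc([N+](=O)[O-])cc1)n1ccc(=O)[nH]c1=O` gives the higher of the two numbers so far in a functional assay on MCF7 cells (Homo sapiens) for antiproliferative activity (a higher number here means a weaker inhibitor, a lower number a stronger inhibitor), at 45800 nM. Compound 2 `O=c1ccn(C2COc3ccccc3CO2)c(=O)[nH]1` gives 1250 nM in this assay, a gap beyond the scatter. Compound 3 `COC(CN(c1ccccc1CO)S(=O)(=O)c1ccc([N+](=O)[O-])cc1)n1c(=O)cc[nH]c1=O` differs from compound 1 by a group of 8 heavy atoms (4 carbon, 2 nitrogen, 2 oxygen; one six-membered aromatic ring with 2 hetero atoms) in place of a group of 8 heavy atoms (4 carbon, 2 nitrogen, 2 oxygen; one six-membered aromatic ring with 2 hetero atoms), on a saturated chain carbon bound to an oxygen on a saturated carbon and a saturated chain carbon, the same atoms joined differently. Among the measured compounds shown here, no step between measured compounds informs this change, so the expected step from compound 1 to compound 3 in this assay is a 1.1-fold lower number from compound 1 to compound 3 (0.06 log units; within the scatter), no more than the scatter, in either direction. Compound 3 is expected to give 40000 nM in this assay, with a range of 10000 nM to 150000 nM.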

Compound 3, half-maximal inhibitory concentration: 55200 nM
For compound 3 the middle estimate is 1.4-fold (0.14 log units) below the measured one; the measured number falls inside the stated range.
By their numbers in this assay, from the lowest: compound 2; then compounds 1 and 3 (each within the scatter of the next).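

In this assay, joining the same atoms differently on the saturated chain carbon gives a 1.2-fold higher number from compound 1 to compound 3 (0.08 log units; within the scatter), so the two ways of attaching this six-membered aromatic ring cannot be told apart at this place. The series' activity at this position therefore does not yet depend on how the ring is attached. Nothing available gives a cause for this result.

Still open, from the compounds shown here alone, is whether an amine or a carboxylic acid in place of the ring at this saturated chain carbon would move the number beyond the scatter.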